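Swapping the Nitrile Arm for a Vinyl Arm on Sulfur

The compounds below may be only part of what the source reports. "The series", "measured", "known", "first", "only" and "open" are said of these compounds alone.

Compound 1 `Cc1ccc(-c2nc(N)c3cc(Cl)ccc3n2)cc1` carries an amino group on its core and, in a functional assay on HeLa cells (Homo sapiens) for antiproliferative activity, read by MTT assay, with a stated time of 48 h (on this read-out higher numbers stand for weaker inhibition and lower numbers for stronger inhibition), compound 1 gives 3.56 ug/mL. Compound 2 `Cc1ccc(-c2nc(SCC#N)c3cc(Cl)ccc3n2)cc1` instead carries a (cyanomethyl)sulfanyl group there, and in this assay compound 2 gives 3.76 ug/mL. That exchange is a 1.1-fold higher number from compound 1 to compound 2 (0.02 log units; within the scatter), so the two compounds are, on the numbers shown, indistinguishable; compound 2 stands beside compound 1, the only other measured compound, with nothing separating them beyond the scatter.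

Compound 3 `C=CCSc1nc(-c2ccc(C)cc2)nc2ccc(Cl)cc12` differs from compound 2 in vinyl in place of cyano on a saturated chain carbon bound to a sulfur. For the measured compounds named here, no measured step touches this chain beyond the sulfur: the single step known alters the group attached to the core, not its tail. With nothing to point either way, the expected step of a 1.0-fold higher number from compound 2 to compound 3 (0.00 log units; within the scatter) is none beyond the scatter. Compound 3 is therefore estimated at 3.8 ug/mL, within a range from 1.9 ug/mL to 7.6 ug/mL.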

Compound 3, half-maximal inhibitory concentration: 9.66 ug/mL
Compound 3: the middle estimate sits 2.5-fold (0.41 log units) below what was measured; measured number outside the range, above it.
By their numbers in this assay, from the lowest: compounds 1 and 2 (each within the scatter of the next); then compound 3.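

The end of the chain on sulfur matters in this assay: there is a 2.6-fold higher number from compound 2 to compound 3 (0.41 log units; beyond the scatter), a change large enough to stand out from the scatter. The (cyanomethyl)sulfanyl group could not be told apart from the amino group, but the allylsulfanyl group can, with a 2.7-fold higher number from compound 1 to compound 3 (0.43 log units; beyond the scatter), so a sulfur link at this position does not by itself fix the number. Here, vinyl in place of cyano gives weaker inhibition.

Nothing shown explains why these two chain ends differ. Going by these compounds, it remains open whether a plain propyl chain, a longer chain, or a chain ending in an amine or a carboxylic acid would sit nearer compound 2 or compound 3, or move beyond both.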